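A Triazole Replaces a Cyanoalkyl Chain on a Fused Core

The compounds below may be only part of what the source reports. "The series", "measured", "known", "first", "only" and "open" are said of these compounds alone.

Of the compounds shown here, three sharing one core have been measured in a physicochemical assay for solubility, in phosphate buffer, with a stated time of 18 h; on this read-out lower numbers stand for lower solubility and higher numbers for higher solubility. Compound 1 `CC(C)Cc1ncc2c(N)c(C#N)c(N)nc2n1` gives 268000 nM in this assay, compound 2 `N#Cc1c(N)nc2nc(Cc3ccccc3)ncc2c1N` gives 13000 nM, and compound 3 `CC(C)(C)c1nc(CCCCC#N)c2c(N)c(C#N)c(N)nc2n1` gives 16000 nM. Compound 3 therefore stands second highest of the three numbers: its value lies within the scatter of that of compound 2, while compound 1 sits clearly higher. Compound 4 `CC(C)(C)c1nc(-c2ncn[nH]2)c2c(N)c(C#N)c(N)nc2n1` differs from compound 3 by 1H-1,2,4-triazol-5-yl in place of 4-cyanobutyl on an aromatic carbon. For the measured compounds named here, the only measured step, a 21-fold lower number from compound 1 to compound 2 (1.31 log units; beyond the scatter), concerns a different position and a different exchange, and bears on the new step only loosely, as another case in which a ring enters in place of a chain; there the number fell by a large amount. Going by the values given here, with no closer precedent, a modest downward step in this assay is expected for compound 4, a 1.6-fold lower number from compound 3 to compound 4 (0.20 log units; within the scatter), with wide uncertainty. Compound 4 is accordingly estimated at 10000 nM, in a range from 2000 nM to 50000 nM.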

Compound 4, solubility: 64500 nM
Compound 4: middle estimate off by 6.5-fold (0.81 log units), on the low side; the whole stated range lies below it.
By their numbers in this assay, from the lowest: compounds 2 and 3 (each within the scatter of the next); then compound 4; then compound 1.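

In this assay, putting 1H-1,2,4-triazol-5-yl in place of 4-cyanobutyl on the aromatic carbon next to the ring nitrogen gives a 4.0-fold higher number from compound 3 to compound 4 (0.61 log units; beyond the scatter), so the number responds upward to this exchange at this position. For the compounds shown here, the only earlier step, a 21-fold lower number from compound 1 to compound 2 (1.31 log units; beyond the scatter), ran the other way at a different position, so across these compounds a ring entering in place of a chain does not fix the direction of the change. The exchange alters the ring count, the nitrile and the hydrogen-bond donors and acceptors all at once, and nothing available here bears on the reason for the step.

As far as these compounds go, it remains open whether a simple amine, a carboxylic acid or a shorter nitrile-bearing chain at this position would move the number as the triazole does. From the compounds shown here alone, whether the step would carry over without the tert-butyl group also remains open.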